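The compounds below may be only part of what the source reports. "The series", "measured", "known", "first", "only" and "open" are said of these compounds alone.

Compound 1 `O=C(Nc1cc(C(F)(F)F)ccc1Nc1ccc(Br)cc1)c1ccncc1`: "not active" (no number reported)
Compound 2 `O=C(Nc1cc(C(F)(F)F)ccc1NC1CCCCC1)c1ccncc1`: 59200 nM
Compound 3 `O=C(Nc1cc(C(F)(F)F)ccc1Nc1ccc(Br)cc1)c1ccccc1`: 11800 nM

In a functional assay on HL-60 cells (Homo sapiens) for cytotoxicity, read by MTT assay, with a stated time of 48 h (on this read-out higher numbers stand for weaker inhibition and lower numbers for stronger inhibition), compound 3 gives 11800 nM, the lower of the two numbers reported; compound 2 gives 59200 nM, which stands beyond the scatter above it, while compound 1 is reported as "not active" (no number reported) without a number. Compound 4 `O=C(Nc1cc(C(F)(F)F)ccc1NC1CCCCC1)c1ccccc1` has not yet been measured. It differs from compound 3 by cyclohexyl in place of 4-bromophenyl on a nitrogen on an aromatic ring. Compound 1 and compound 2 carry the same two groups under another amide, but their two values only show compound 1 at "not active" (no number reported) and compound 2 at 59200 nM. For compound 4 a value of 20000 nM is estimated, between 5000 nM and 80000 nM. The expected step of a 1.7-fold higher number from compound 3 to compound 4 (0.23 log units; within the scatter) is a weakening that may not exceed the scatter.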

Compound 4, half-maximal inhibitory concentration: 34900 nM
Estimate against measurement, compound 4: 1.7-fold (0.24 log units) below, and the stated range covers the measured number.
By their numbers in this assay, from the lowest: compound 3; then compounds 4 and 2 (each within the scatter of the next).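

In this assay, cyclohexyl in place of 4-bromophenyl on a nitrogen on an aromatic ring gives a 3.0-fold higher number from compound 3 to compound 4 (0.47 log units; beyond the scatter), so with the phenyl amide this position now has a step beyond the scatter. Phenyl in place of pyridin-4-yl on a carbonyl carbon gives a 1.7-fold lower number from compound 2 to compound 4 (0.23 log units; within the scatter), so with cyclohexyl on that nitrogen the swap does not separate the two compounds. The compounds shown leave open how a phenyl without the bromine or an open chain such as n-butyl on that nitrogen would read. No supporting measurement explains the step at this position.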